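A few compounds are considered here, and "the series" means these few. Any claim that something is new, unique, unknown or untested is made for them only; others in the source may bear on it.

Measured so far in a physicochemical assay for solubility, read by HPLC, using the shake flask method, measured as kinetic solubility, with a stated time of 2 h, at pH 7.4; a lower number here means a less soluble compound, a higher number a more soluble compound:
compound 1 `Cc1cc(N(C)Cc2ccccn2)n2nc(C)c(-c3ccccc3)c2n1` gives 17500 nM.
compound 2 `COc1ccc(-c2c(C)nn3c(NCc4ccccn4)cc(C)nc23)cc1` gives < 5000 nM, a limit of the assay and not a number.
compound 3 `Cc1cc(NCc2ccccn2)n2ncc(-c3ccccc3C)c2n1` gives < 5000 nM, again a limit rather than a number.

Compound 3 thus stands at the limit of < 5000 nM in this assay, at which 2 of the 3 values shown sit; only compound 1 returns a number in this assay. Compound 4 `Cc1cc(NCc2ccccn2)n2ncc(-c3cccc(N(C)C)c3)c2n1` differs from compound 3 in one place: 3-(dimethylamino)phenyl in place of 2-methylphenyl on an aromatic carbon. Going by the values given here, no measured step gives a size for this change. With compound 3 at the limit of < 5000 nM in this assay, at which 2 of the 3 values shown sit, the expected direction is upward, a step beyond the scatter into the measurable range, though the limit leaves the size open. For compound 4 the estimate is 9000 nM, with a range from 2500 nM to 30000 nM. That estimate means an expected step of an at least 1.8-fold higher number from compound 3 to compound 4 (0.25 log units; that floor lies within the scatter).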

Compound 4, solubility: 94600 nM
Compound 4: middle estimate off by 11-fold (1.02 log units), on the low side; the measured number lies above the stated range.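

In this assay, 3-(dimethylamino)phenyl in place of 2-methylphenyl gives an at least 18-fold higher number from compound 3 to compound 4 (1.27 log units; beyond the scatter). The earlier compounds shown here offered no step, and this one shows that a change at this aromatic carbon alone can move a compound from the limit into the measurable range. The step is only a floor, since compound 3 starts from a limit and not a number: the limit of < 5000 nM in this assay, at which 2 of the 4 values shown sit.

One step cannot separate the loss of 2-methylphenyl from the entry of 3-(dimethylamino)phenyl. From the compounds shown here alone, how a morpholine or a carboxylic acid on the phenyl ring would read remains open.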